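The source may report more compounds than this note shows. Statements on the series, on what has been measured and on what is new or still open speak of the compounds shown alone.

Measured compounds:
compound 1, `CC1CCN(C2CCN(S(=O)(=O)c3cccnc3)CC2)CC1` — 2400 nM
compound 2, `CC1CCN(C2CCN(S(=O)(=O)c3ccc(-c4ccc(Cl)cc4)cc3)CC2)CC1` — 105 nM
compound 3, `CC1CCN(C2CCN(S(=O)(=O)c3ccc(C(C)C)cc3)CC2)CC1` — 685 nM

All three share one core and differ only in the group carried on the sulfonyl sulfur. In a functional assay on DLD-1 cells (Homo sapiens) for antiproliferative activity, read by CellTiter-Glo, with a stated time of 72 h (on this read-out higher numbers stand for weaker inhibition and lower numbers for stronger inhibition), compound 1 gives the highest of the three numbers; compound 3 sits nearest to it and compound 2 furthest, both gaps beyond the scatter. Within the data shown here, the single one-place step among the measured pairs, a 6.5-fold higher number from compound 2 to compound 3 (0.81 log units; beyond the scatter), shows that the group on the phenyl ring shifts the read-out by a modest amount.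

Among the measured compounds shown here, compound 4, `CC1CCN(C2CCN(S(=O)(=O)c3ccc(Cl)cc3Cl)CC2)CC1`, is not yet measured. 2,4-dichlorophenyl in place of pyridin-3-yl on a sulfonyl sulfur Both measured compounds that carry a phenyl group on the sulfonyl sulfur, compound 2 and compound 3, give lower numbers than compound 1, and this is what bears on the change; no measured pair has pyridin-3-yl leaving, and none carries a 2,4-dichlorophenyl. A step down from compound 1 is therefore expected, a 6.0-fold lower number from compound 1 to compound 4 (0.78 log units; beyond the scatter). The number for compound 4 would then sit between those of compound 3 and compound 2. The estimate for compound 4 is 400 nM, with a range from 150 nM to 1200 nM.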

Compound 4, half-maximal inhibitory concentration: 1 nM
The estimate for compound 4 lay 400-fold (2.60 log units) above the measured number; measured number below the stated range.
By their numbers in this assay, from the lowest: compound 4; then compound 2; then compound 3; then compound 1.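

In this assay, among these compounds, 2,4-dichlorophenyl in place of pyridin-3-yl on the sulfonyl sulfur brings a 2400-fold lower number from compound 1 to compound 4 (3.38 log units; beyond the scatter), far beyond the earlier step of a 6.5-fold higher number from compound 2 to compound 3 (0.81 log units; beyond the scatter), so the read-out responds to this position much more strongly than the earlier compounds showed. Compound 4 (1 nM) also gives a lower number than compound 2 (105 nM), so the 4-chlorophenyl carried by compound 2 is not required for a low number here. Nothing measured on these compounds accounts for the size of this step.

The compounds shown do not separate the contribution of each chlorine in 2,4-dichlorophenyl from the departure of the pyridine nitrogen. Also open, from the compounds shown here alone, is whether the low number holds with a methoxy group or a nitrile in place of either chlorine, or with a different amine in place of the one in the shared core.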